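Cyclopentyl in Place of Hydrogen: Expectation Before Measurement

This account rests on a few compounds, and the source may have more. Where it says the series, first, only, none or still open, it means among the compounds named here.

Of the compounds shown here, three have so far been measured in a functional assay on MDA-MB-231 cells (Homo sapiens) for antiproliferative activity, read by MTT assay, with a stated time of 24 h; on this read-out higher numbers stand for weaker inhibition and lower numbers for stronger inhibition. Compound 1 `c1ccc(-c2noc(-c3ccncc3)n2)cc1` reaches only the limit of the assay, giving > 1000000 nM. Compound 3 `COc1cc(-c2noc(-c3ccncc3)n2)ccc1OCc1ccccc1` likewise returns a limit, > 1000000 nM. Compound 2 `COc1ccc(-c2noc(-c3ccc(F)cc3)n2)cc1O` stands at a limit as well with > 1000000 nM, so no number separates it from its companions; this is the limit of > 1000000 nM in this assay, at which 3 of the 3 values shown sit. Compound 4 `COc1ccc(-c2noc(-c3ccc(F)cc3)n2)cc1OC1CCCC1` differs from compound 2 in one place: cyclopentyl in place of hydrogen on an oxygen on an aromatic ring. For the measured compounds named here, no step between measured compounds exists to calibrate such a change. With every measured value sitting at the limit, the expected step of a number no higher from compound 2 to compound 4 (the limit leaves the size open) is most likely none beyond the scatter. Compound 4 is therefore estimated at 1000000 nM, within a range from 200000 nM to 1000000 nM, and a further limit is the likeliest outcome.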

Compound 4, half-maximal inhibitory concentration: 55500 nM
Beside the measured number, compound 4's estimate is 18-fold (1.26 log units) above it; the measured number lies below the stated range.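

In this assay, cyclopentyl in place of hydrogen on an oxygen on an aromatic ring gives an at least 18-fold lower number from compound 2 to compound 4 (1.25 log units; beyond the scatter), which shows that this oxygen is a place where a single change can move the read-out. From the compounds shown here alone, the step starts from a limit for compound 2, so its full size remains open. Compound 4 alone gives a number rather than a limit: the limit of > 1000000 nM in this assay, at which 3 of the 4 values shown sit.

Going by these compounds, whether a methyl group, a longer chain or an amine on this oxygen would also lower the number remains open. So does whether the ring of carbon itself matters.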